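Swapping the nitrophenyl end of a hydrazone for a styryl chain

A few compounds are considered here, and "the series" means these few. Any claim that something is new, unique, unknown or untested is made for them only; others in the source may bear on it.

Measured so far:
Compound 1, `O=C(CSc1nnc(-c2ccncc2)o1)N/N=C/c1cccc(C(F)(F)F)c1`: 14600 nM
Compound 2, `O=C(CSc1nnc(-c2ccncc2)o1)N/N=C/c1ccccc1[N+](=O)[O-]`: 35600 nM

Of the compounds shown here, two sharing one core have been tested in a functional assay on MCF7 cells (Homo sapiens) for cytotoxicity, read by MTT assay, with a stated time of 48 h; on this read-out lower numbers stand for stronger inhibition and higher numbers for weaker inhibition. Compound 1 gives 14600 nM. Compound 2 gives 35600 nM, the higher of the two numbers, so compound 2 is the weaker of the pair and the gap between them is beyond the scatter.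

The next compound, compound 3, `O=C(CSc1nnc(-c2ccncc2)o1)N/N=C/C=C/c1ccccc1`, keeps everything except the group on the carbon with a double bond to nitrogen. The change is 2-phenylethenyl in place of 2-nitrophenyl on a carbon with a double bond to nitrogen. Both the leaving group and the entering group carry one six-membered aromatic ring of carbon only and one double bond outside aromatic rings, so the overall shape of that end is kept while the nitro part is dropped.

Within the data shown here, no measured pair shows what this kind of exchange does on this core, so the expectation rests on the two values alone. In this assay the step is expected to be modest, most likely a slight move toward lower numbers, and possibly none beyond the scatter. The expected step is a 1.8-fold lower number from compound 2 to compound 3 (0.25 log units; within the scatter), taken as an estimate rather than a known result.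

Compound 3 is therefore estimated at 20000 nM, with a plausible range from 6000 nM to 70000 nM.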

Compound 3, half-maximal inhibitory concentration: 10800 nM
The estimate for compound 3 lay 1.9-fold (0.27 log units) above the measured number, and the stated range covers the measured number.
By their numbers in this assay, from the lowest: compounds 3 and 1 (each within the scatter of the next); then compound 2.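

In this assay, the group on the carbon with a double bond to nitrogen clearly affects the result: 2-phenylethenyl in place of 2-nitrophenyl gives a 3.3-fold lower number from compound 2 to compound 3 (0.52 log units; beyond the scatter), a modest step but one beyond the scatter. Among these compounds, this is the first change at a single place on the shared core whose size can be read. The entering group keeps the six-membered aromatic ring of carbon only and the one double bond outside aromatic rings, yet it has no nitrogen, no oxygen and no hydrogen-bond acceptors, so this place does not need those nitro atoms to keep the activity seen in this read-out. No measurement shown here bears on why the number falls.

Two things change together in this step: the nitro part goes and the phenyl ring moves out along a two-carbon chain, and the compounds shown cannot tell which of the two matters. A saturated 2-phenylethyl chain or an unsubstituted phenyl ring on the same carbon would begin to separate them, and an amine or a carboxylic acid on the ring of the chain would test how far this end can vary.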